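From bromo to butyl: an expected step in growth inhibition

A few compounds are considered here, and "the series" means these few. Any claim that something is new, unique, unknown or untested is made for them only; others in the source may bear on it.

Compound 1 `O=C(NO)c1cnc(N2C[C@@H]3[C@H](C2)[C@H]3NC(=O)c2cccs2)nc1` gives 3600 nM
Compound 2 `O=C(NO)c1cnc(N2C[C@@H]3[C@H](C2)[C@H]3NCc2ccc(Br)cc2)nc1` gives 250 nM
Compound 3 `O=C(NO)c1cnc(N2C[C@@H]3[C@H](C2)[C@H]3NCc2cc(F)cc(F)c2)nc1` gives 200 nM

All three compounds were tested in a functional assay on HCT-116 cells (Homo sapiens) for antiproliferative activity, read by WST assay, with a stated time of 72 h (a lower number here means a stronger inhibitor of growth, a higher number a weaker inhibitor of growth), and share one core. There, compound 2 (250 nM) lies within the scatter of compound 3 (200 nM), while compound 1 stands well apart from both. Compound 4 `CCCCc1ccc(CN[C@H]2[C@@H]3CN(c4ncc(C(=O)NO)cn4)C[C@@H]32)cc1` differs from compound 2 in one place, with butyl in place of bromo on an aromatic carbon. The closest measured precedent also changes the substituents on this aromatic ring, and it shows a 1.3-fold lower number from compound 2 to compound 3 (0.10 log units; within the scatter) as its size. The much larger a 14-fold lower number from compound 1 to compound 2 (1.16 log units; beyond the scatter) belongs to a change on the amine nitrogen, so it says little about this one. Among the compounds with values here, no measured compound carries butyl on the ring, so the evidence is indirect. In this assay no step beyond the scatter is therefore expected, and the estimated change is a 1.3-fold lower number from compound 2 to compound 4 (0.10 log units; within the scatter) as the likely outcome. Compound 4 is estimated at 200 nM with an expected range from 70 nM to 600 nM on measurement.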

Compound 4, concentration for 50% growth inhibition: 410 nM
The estimate for compound 4 lay 2.1-fold (0.31 log units) below the measured number, and the stated range covers the measured number.
By their numbers in this assay, from the lowest: compounds 3, 2 and 4 (each within the scatter of the next, the first and the last beyond it); then compound 1.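

In this assay, butyl in place of bromo on an aromatic carbon gives a 1.6-fold higher number from compound 2 to compound 4 (0.21 log units; within the scatter), so this place, para to a large group, takes butyl with its four heavy atoms where bromo has one, with no step beyond the scatter. Until now the ring had carried only halogens, bromo in compound 2 and fluoro groups in compound 3, and compound 4 extends what is known here to a carbon chain. No measurement shown here gives a reason why this exchange stays within the scatter.

Going by these compounds, it remains open whether a longer chain on this aromatic carbon would also stay within the scatter of compound 2. Also open, on these data alone, is how an amine or a carboxylic acid at this place would compare with bromo and butyl.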